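Swapping an aromatic group for a hydroxyl-bearing chain

This account rests on a few compounds, and the source may have more. Where it says the series, first, only, none or still open, it means among the compounds named here.

Measured compounds:
compound 1, `CCCCc1cn(C(c2ccccc2)c2cc3cc(Br)ccc3nc2OC)nn1`: 11.1%
compound 2, `CCOC(=O)c1cn(C(c2ccccc2)c2cc3cc(Br)ccc3nc2OC)nn1`: 2.01%
compound 3, `COc1nc2ccc(Br)cc2cc1C(c1ccccc1)n1cc(-c2cccc(F)c2)nn1`: 12.7%

For the measured compounds named here, in an ADME assay on SK-OV-3 cells (Homo sapiens) for cytotoxicity, read by sulforhodamine B assay, with a stated time of 48 h, tested at 10 uM (on this read-out higher numbers stand for more inhibition at the one concentration tested (going by the name of the read-out) and lower numbers for less inhibition), compound 3 gives the highest of the three numbers, yet its gap to compound 1 is within the usual scatter, so only the step of a number 10.7 percentage points higher from compound 2 to compound 3 (beyond the scatter) sets it apart. Compound 4, `COc1nc2ccc(Br)cc2cc1C(c1ccccc1)n1cc(CCCCCO)nn1`, is not yet measured. It differs from compound 3 in one place: 5-hydroxypentyl in place of 3-fluorophenyl on an aromatic carbon.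

Going by the values given here, two measured steps bear on this. The step of a number 1.6 percentage points higher from compound 1 to compound 3 (within the scatter) shows that a plain chain and the 3-fluorophenyl group give about the same number, and the step of a number 9.1 percentage points lower from compound 1 to compound 2 (within the scatter) also stayed within the scatter. Only a number 10.7 percentage points higher from compound 2 to compound 3 (beyond the scatter) went beyond it. A 5-hydroxypentyl chain resembles the butyl chain of compound 1 more than the ethoxycarbonyl of compound 2, so no step beyond the scatter is expected in this assay; the estimated step is a number 2.7 percentage points lower from compound 3 to compound 4 (within the scatter).

Compound 4 is therefore expected to give 10%, with a range from 0% to 22%.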

Compound 4, a percentage reported as inhibition, at one concentration (the size of the read-out at that concentration, not a potency): 8.69%
The estimate for compound 4 lay 1.3 percentage points above the measured number; the range from low to high includes it.
By their numbers in this assay, from the lowest: compounds 2, 4, 1 and 3 (each within the scatter of the next, the first and the last beyond it).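

In this assay, this carbon of the five-membered aromatic ring with 3 nitrogen can carry an open chain ending in a hydroxyl rather than an aromatic ring without a change beyond the scatter: exchanging 3-fluorophenyl for 5-hydroxypentyl gives a number 4 percentage points lower from compound 3 to compound 4 (within the scatter). Extending the butyl chain by a hydroxymethyl also leaves the result within the scatter, with a number 2.4 percentage points lower from compound 1 to compound 4 (within the scatter). Compound 4 is not separated from the ester either, at a number 6.7 percentage points higher from compound 2 to compound 4 (within the scatter), so the step from compound 2 to compound 3 remains the only one beyond the scatter.

The data offer no explanation for how these numbers fall. From the compounds shown here alone, whether an amine or a carboxylic acid at the end of the chain, or a longer chain, would give a number beyond the scatter remains open.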